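Trifluoromethyl to methoxy in a growth-inhibition set

The source may hold more compounds than are shown below. What is called first, only, known or untested is meant among the compounds shown, and "the series" means these compounds.

Values in a functional assay on ZR-75-1 cells (Homo sapiens) for inhibition, read by sulforhodamine B assay (on this read-out lower numbers stand for stronger inhibition of growth and higher numbers for weaker inhibition of growth), are as follows.
Compound 1 `FC(F)(F)c1ccc(-c2ccc(-c3ccc(-c4nc5ccccc5[nH]4)cc3)cc2)cc1` gives 48300 nM
Compound 2 `Oc1cccc2[nH]c(-c3ccc(-c4ccc(-c5ccc(F)cc5)cc4)cc3)nc12` gives 6320 nM
Compound 3 `Oc1cccc2[nH]c(-c3ccc(-c4ccc(-c5ccc(C(F)(F)F)cc5)cc4)cc3)nc12` gives 5110 nM

Compound 3 (5110 nM) sits within the scatter of compound 2 and clearly under compound 1 on this read-out. Compound 4 `COc1ccc(-c2ccc(-c3ccc(-c4nc5c(O)cccc5[nH]4)cc3)cc2)cc1` is not yet measured. It departs from compound 3 by one change (methoxy in place of trifluoromethyl on an aromatic carbon) with methoxy in place of trifluoromethyl on an aromatic carbon, para to a large group.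

The nearest measured change, trifluoromethyl in place of fluoro, gave a 1.2-fold lower number from compound 2 to compound 3 (0.09 log units; within the scatter) and stayed within the scatter. The step of a 9.5-fold lower number from compound 1 to compound 3 (0.98 log units; beyond the scatter) was beyond the scatter, but it came from hydroxy in place of hydrogen on an aromatic carbon, and compound 4 keeps that hydroxy. Within the data shown here, no measured compound carries methoxy, so this reading is indirect. A step beyond the scatter is therefore not expected in either direction. The estimated change is small (a 1.1-fold higher number from compound 3 to compound 4 (0.06 log units; within the scatter)). In this assay compound 4 is expected at 5800 nM within an estimated range (2500 nM to 13000 nM).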

Compound 4, concentration for 50% growth inhibition: 8200 nM
Compound 4: the middle estimate sits 1.4-fold (0.15 log units) below what was measured; low and high end bracket the measured number.
By their numbers in this assay, from the lowest: compounds 3, 2 and 4 (each within the scatter of the next); then compound 1.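

In this assay this position, on an aromatic carbon para to a large group, now holds a methoxy group with a hydrogen-bond acceptor, and the read-out does not separate it from the two groups without one: a 1.6-fold higher number from compound 3 to compound 4 (0.21 log units; within the scatter) and a 1.3-fold higher number from compound 2 to compound 4 (0.11 log units; within the scatter) both lie within the scatter. Across fluoro, trifluoromethyl and methoxy on the hydroxy-bearing core, the number therefore shows no dependence on the group at this position, and the only step beyond the scatter remains the hydroxy change, a 9.5-fold lower number from compound 1 to compound 3 (0.98 log units; beyond the scatter). No independent measurement bears on why these three groups read alike.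

As far as these compounds go, whether an amine, a carboxylic acid or a longer chain such as butoxy would also leave the number in place remains open. The hydroxy step is shown only with trifluoromethyl present, so its size with methoxy is also unknown.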